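A Fluorine Swap on a Stable Scaffold

A few compounds are considered here, and "the series" means these few. Any claim that something is new, unique, unknown or untested is made for them only; others in the source may bear on it.

Measured compounds:
Compound 1 `Cn1cc(-c2cc3c(-c4cccc(N5CCC[C@H](N)C5)n4)nn(C)c3cn2)cn1`: 91%
Compound 2 `Cc1cncc(-c2ccc3cnn(-c4cccc(N5CCCNCC5)n4)c3c2)n1`: 84%

In an ADME assay on microsomes from intestine (Rattus norvegicus) for metabolic stability, using NADPH, with a stated time of 60 min (on this read-out higher numbers stand for a more stable compound and lower numbers for a less stable compound), compound 1 gives 91%, and in the same assay compound 2 gives 84%. The two numbers lie within the usual scatter of each other, so compound 2 cannot be set apart from compound 1 on this read-out. Compound 3 `Cc1cncc(-c2cc(F)c3cnn(-c4cccc(N5CCCNCC5)n4)c3c2)n1` differs from compound 2 by fluoro in place of hydrogen on an aromatic carbon. Within the data shown here, no step between two measured compounds involves this kind of change, so nothing here points to a shift in either direction beyond the scatter. Compound 3 is therefore expected to stay close to compound 2, with an expected step of a number 1 percentage points higher from compound 2 to compound 3 (within the scatter). The estimate for compound 3 in this assay is 85%, expected to fall between 70% and 96%.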

Compound 3, percent of the compound remaining: 107%
The estimate for compound 3 lay 22 percentage points below the measured number; the measured number lies above the stated range.
By their numbers in this assay, from the lowest: compounds 2 and 1 (each within the scatter of the next); then compound 3.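

In this assay, fluoro in place of hydrogen on this aromatic carbon, ortho to a fused ring, brings a number 23 percentage points higher from compound 2 to compound 3 (beyond the scatter). This shows that a change of just 1 heavy atom at this position can move the read-out beyond the usual scatter, which the two earlier compounds could not show. The data shown offer no explanation for this rise.

On these data alone, it remains open whether chloro, methoxy or an amine at this position would move the number in the same direction. As far as these compounds go, it is also open whether fluoro on another aromatic carbon would do so.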